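Hydroxy for ethyl on the side chain of compound 2

The source may hold more compounds than are shown below. What is called first, only, known or untested is meant among the compounds shown, and "the series" means these compounds.

Measured compounds:
compound 1, `CC[C@H](C)[C@H](NC(=O)CN(c1nc(Cl)nc2[nH]cnc12)C1CC1)C(=O)OCc1ccccc1`, 40.6%
compound 2, `CC[C@H](C)[C@H](NC(=O)CN(c1ncnc2c1ncn2C1CCCCO1)C1CC1)C(=O)OCc1ccccc1`, 27.4%
compound 3, `NC(=O)C[C@H](NC(=O)CN(c1nc(Cl)nc2[nH]cnc12)C1CC1)C(=O)OCc1ccccc1`, 36.4%

In a functional assay on the whole organism (Tail, strain ICR) with Mus musculus as the target, in the tail flick test, with a stated time of 60 min, at a dose of 25 umol/kg by the oral route (a lower number here means a weaker effect, a higher number a stronger effect of the compound at the dose given), compound 2 gives 27.4%, the smallest of the three numbers. Compound 1 stands above it by more than the usual scatter, whereas compound 3 lies within the scatter of compound 2, so no order between those two can be read.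

Compound 4, `C[C@@H](O)[C@H](NC(=O)CN(c1ncnc2c1ncn2C1CCCCO1)C1CC1)C(=O)OCc1ccccc1`, has not yet been measured. It differs from compound 2 by hydroxy in place of ethyl on a saturated chain carbon bound to two saturated chain carbons; cut one bond further out, the change reads sec-butyl to 1-hydroxyethyl.

Going by the values given here, the only measured step at a related place is a number 4.2 percentage points lower from compound 1 to compound 3 (within the scatter), in which sec-butyl gave way to carbamoylmethyl on the core of compound 1 and the number barely moved. Among the compounds with values here, no measured pair exchanges ethyl for hydroxy, so the step cannot be read off directly. Given that the one side-chain exchange available stayed within the scatter, compound 4 is expected to move no further than the scatter from compound 2, with a number 0.6 percentage points higher from compound 2 to compound 4 (within the scatter) as the expected step. The estimate for compound 4 in this assay is 28%, with a range from 15% to 42%.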

Compound 4, a percentage reported as activity, at one dose (the size of the read-out at that dose, not a potency): 28.4%
Compound 4: the middle estimate sits 0.4 percentage points below what was measured, and the stated range covers the measured number.
By their numbers in this assay, from the lowest: compounds 2, 4, 3 and 1 (each within the scatter of the next, the first and the last beyond it).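

In this assay, the exchange of ethyl for hydroxy on a saturated chain carbon bound to two saturated chain carbons gives a number 1 percentage points higher from compound 2 to compound 4 (within the scatter), so this change, read one bond further out as sec-butyl to 1-hydroxyethyl, has no effect that this read-out can resolve at the dose given. Going by these compounds alone, the earlier compounds held only one side-chain exchange, a number 4.2 percentage points lower from compound 1 to compound 3 (within the scatter), and that was on the core of compound 1; the new step shows that a side-chain exchange on the core of compound 2 also stays within the scatter, even though the entering hydroxy brings a hydrogen-bond donor and a hydrogen-bond acceptor that the leaving ethyl does not have. No measurement of any property is at hand to account for this result.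

The compounds shown leave open whether an amine or a carboxylic acid on this carbon, or a longer chain, would move the number beyond the scatter. They also leave open whether hydroxy in place of ethyl would give a step of similar size on the core of compound 1.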